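The source may report more compounds than this note shows. Statements on the series, on what has been measured and on what is new or still open speak of the compounds shown alone.

Measured so far:
Compound 1 `COc1ccc(/C=C2\CN(C)C/C(=C\c3ccccc3F)C2=O)cc1OC` gives 10500 nM
Compound 2 `COc1cc(/C=C2\CN(C)C/C(=C\c3ccccc3F)C2=O)cc(OC)c1OC` gives 12100 nM

In an ADME assay on L02 cells (Homo sapiens) for cytotoxicity, read by MTT assay, with a stated time of 24 h (a lower number here means a stronger inhibitor, a higher number a weaker inhibitor), compound 2 stands at 12100 nM and compound 1 at 10500 nM on the same footing, since the two lie within the scatter of each other. Compound 3 `COc1cc(/C=C2\CN(C)C/C(=C\c3ccc(Cl)cc3)C2=O)cc(OC)c1OC` has not yet been measured. It differs from compound 2 as follows: 4-chlorophenyl in place of 2-fluorophenyl on a double-bonded chain carbon bound to a double-bonded ring carbon with 4-chlorophenyl in place of 2-fluorophenyl on a double-bonded chain carbon bound to a double-bonded ring carbon. For the measured compounds named here, no measured step touches that place. Going by the values given here, the sole measured step is a 1.2-fold higher number from compound 1 to compound 2 (0.06 log units; within the scatter) for methoxy in place of hydrogen on an aromatic carbon. That change lies elsewhere in the molecule and stayed within the scatter, so it offers only a weak guide here. No direction can be argued from it, and no shift beyond the scatter is expected. The estimated move is a 1.1-fold lower number from compound 2 to compound 3 (0.04 log units; within the scatter) and no more than repeat measurements alone would give. In this assay the estimate for compound 3 is 11000 nM with an expected range of 5000 nM to 24000 nM for such a measurement.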

Compound 3, half-maximal inhibitory concentration: 14000 nM
Compound 3: the middle estimate sits 1.3-fold (0.10 log units) below what was measured; the range from low to high includes it.
By their numbers in this assay, from the lowest: compounds 1, 2 and 3 (each within the scatter of the next).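

In this assay, for the compounds shown here, the first reading at this place, on a double-bonded chain carbon bound to a double-bonded ring carbon, comes from putting 4-chlorophenyl in place of 2-fluorophenyl, and it gives a 1.2-fold higher number from compound 2 to compound 3 (0.06 log units; within the scatter) as its result. Going by these compounds alone, the earlier step concerned a methoxy group on the other aromatic ring, so this shows for the first time that the aryl group at this place can be exchanged with no shift beyond the scatter, at least for this one pair of groups. Nothing available explains why the number held steady in this exchange.

The step changes both the halogen and its place on the phenyl ring at once, so the compounds shown cannot separate the two, and 2-chlorophenyl or 4-fluorophenyl would be needed to do so. They also leave open whether a group of a different kind at this place, such as an amine, a carboxylic acid or a longer chain in place of the halogen, would move the number beyond the scatter.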